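Adding one fluoro to the phenyl ring of compound 2

A few compounds are considered here, and "the series" means these few. Any claim that something is new, unique, unknown or untested is made for them only; others in the source may bear on it.

In a functional assay on MV4-11 cells (Homo sapiens) for antiproliferative activity, read by CCK-8 assay, with a stated time of 72 h (on this read-out lower numbers stand for stronger inhibition and higher numbers for weaker inhibition), compound 1 `COc1cccc(-c2cn(C)c(=O)c3[nH]c(C(=O)NCc4ccc(C(=O)Nc5ccccc5N)cc4)cc23)c1` gives 250 nM. Compound 2 `Cn1cc(-c2ccccc2)c2cc(C(=O)NCc3ccc(C(=O)Nc4ccccc4N)cc3)[nH]c2c1=O` gives 230 nM, so these two compounds stand level, within the usual scatter of repeated measurements. Compound 3 `Cn1cc(-c2cccc(F)c2)c2cc(C(=O)NCc3ccc(C(=O)Nc4ccccc4N)cc3)[nH]c2c1=O` has not yet been measured. It turns the phenyl of compound 2 into 3-fluorophenyl, with fluoro in place of hydrogen on an aromatic carbon, meta to a large group: fluoro in place of hydrogen on an aromatic carbon.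

For the measured compounds named here, only one measured step bears on this change. It puts hydrogen in place of methoxy on an aromatic carbon, and it is small: a 1.1-fold lower number from compound 1 to compound 2 (0.04 log units; within the scatter). On this single step, no change beyond the scatter is expected in this assay, and the estimated step is a 1.1-fold lower number from compound 2 to compound 3 (0.04 log units; within the scatter). The expected value for compound 3 is 210 nM, with an estimated range of 100 nM to 450 nM.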

Compound 3, half-maximal inhibitory concentration: 210 nM
For compound 3 middle estimate and measured number coincide at the digits printed, and the stated range covers the measured number.
By their numbers in this assay, from the lowest: compounds 3, 2 and 1 (each within the scatter of the next).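

In this assay a single fluoro on this phenyl ring brings no change beyond the scatter, with a 1.1-fold lower number from compound 2 to compound 3 (0.04 log units; within the scatter) as the step from adding it. Fluoro and methoxy at this place also stand level, with a 1.2-fold lower number from compound 1 to compound 3 (0.08 log units; within the scatter) as the step between them. Hydrogen, methoxy and fluoro therefore give numbers that cannot be told apart here, and nothing available explains why they stand level.

On these data alone, what stays open is whether an amine, a carboxylic acid or a longer chain such as butoxy on this ring would move the number beyond the scatter. Three level values also give no sign of whether fluoro would read the same elsewhere on the ring, or of which groups at this place would separate from hydrogen.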